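The compounds below may be only part of what the source reports. "The series", "measured", "known", "first", "only" and "open" are said of these compounds alone.

The study looks at one shared core in an ADME assay on MDBK cells (Bos taurus) for cytotoxicity; a lower number here means that less compound is tolerated, a higher number that more compound is tolerated. Compound 2 `c1ccc(-c2nc3cc[nH]cc-3n2)cc1` carries a hydrogen on the aromatic nitrogen of this core. In this assay compound 2 gives > 100000 nM, which is a limit of the assay rather than a number. Compound 1 `c1ccc(CCCn2ccc3nc(-c4ccccc4)nc-3c2)cc1` is a related compound with a larger substituent. In this assay compound 1 gives > 100000 nM, again a limit. Among the compounds with values here, both values sit at the limit of > 100000 nM in this assay, at which 2 of the 2 values shown sit, so compound 2 stands at the limit together with the only other value shown, and the two values do not separate the compounds. Compound 3 `c1ccc(-c2nc3ccn(Cc4ccncc4)cc-3n2)cc1` differs from compound 2 by (pyridin-4-yl)methyl in place of hydrogen on an aromatic nitrogen. Within the data shown here, no step between measured compounds is available. The step from compound 2 to compound 3 is expected to be none beyond the scatter, a number no higher from compound 2 to compound 3 (the limit leaves the size open). For compound 3 the estimated value is 100000 nM and the expected range runs from an expected low end of 40000 nM to an expected high end of 250000 nM, most likely again reported as a limit.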

Compound 3, half-maximal cytotoxic concentration: > 100000 nM
Compound 3: a limit, no number; the forecaster's own chance of this, stated with the estimate: 75%; the middle value lies on the limit itself.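

In this assay compound 3 gives > 100000 nM, which is a limit of the assay. No step from compound 2 or compound 1 to compound 3 can be read: the limit of > 100000 nM in this assay, at which 3 of the 3 values shown sit.

The compounds shown leave open whether any substituent on the aromatic nitrogen alters how much of the shared core is tolerated.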